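Benzyl amide swap on the shared core: cytotoxicity notes

This account rests on a few compounds, and the source may have more. Where it says the series, first, only, none or still open, it means among the compounds named here.

In a functional assay on HEY cells (Homo sapiens) for cytotoxicity, read by MTT assay, with a stated time of 72 h (on this read-out higher numbers stand for weaker inhibition and lower numbers for stronger inhibition), compound 1 (`N[C@H]1CC[C@H](Nc2c(C(=O)NCc3ccc(F)cc3)nc(Br)c3cccnc23)CC1`) stands at "not determined" (no result reported), so the step starts from no number. Compound 2 (`N[C@H]1CC[C@H](NC(=O)c2nc(Br)c3cccnc3c2NCc2ccc(F)cc2)CC1`) gives 7100 nM, and compound 3 (`N[C@H]1CC[C@H](Nc2c(C(=O)NCc3ccc(Cl)cc3)nc(Br)c3cccnc23)CC1`) gives 1000 nM. Compound 4 (`N[C@H]1CC[C@H](Nc2c(C(=O)NCc3cccc(C(F)(F)F)c3)nc(Br)c3cccnc23)CC1`) departs from compound 1 as follows: 3-(trifluoromethyl)phenyl in place of 4-fluorophenyl on a saturated chain carbon bound to an amide-type nitrogen. In words, this is 3-(trifluoromethyl)phenyl in place of 4-fluorophenyl on a saturated chain carbon bound to an amide-type nitrogen. Among the compounds with values here, no measured step covers this change. The amide arrangement of compound 3 at 1000 nM is the closest reference, and no shift in this assay beyond the scatter of that value is expected, in either direction. The estimate for compound 4 is 1200 nM, with an expected range of 400 nM to 3500 nM.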

Compound 4, half-maximal inhibitory concentration: 12000 nM
Compound 4: the middle estimate sits 10-fold (1.00 log units) below what was measured, outside the stated range (above it).
By their numbers in this assay, from the lowest: compound 3; then compounds 2 and 4 (each within the scatter of the next).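

Within the data shown here, this is the first readable step at the aryl group on a saturated chain carbon bound to an amide-type nitrogen, and that group proves not to be interchangeable on the shared core. In this assay, a 12-fold higher number from compound 3 to compound 4 (1.08 log units; beyond the scatter) arises from 3-(trifluoromethyl)phenyl in place of 4-chlorophenyl. Nothing at hand bears on the cause of this step.

Going by these compounds, the step changes both the group and its printed ring position, so the share of each stays open. A 3-chlorophenyl or 4-(trifluoromethyl)phenyl group on the same core would separate the two.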